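This account rests on a few compounds, and the source may have more. Where it says the series, first, only, none or still open, it means among the compounds named here.

Measured in a functional assay on DU-145 cells (Homo sapiens) for cytotoxicity, read by CCK-8 assay; a higher number here means a weaker inhibitor, a lower number a stronger inhibitor:
compound 1 `Oc1ccccc1-c1cc(-c2cccs2)cc(-c2ccccc2O)n1`: > 50000 nM (a limit, not a number)
compound 2 `Oc1cccc(-c2cc(-c3cccs3)cc(-c3ccccc3O)n2)c1`: 9300 nM
compound 3 `Oc1ccc(-c2cc(-c3cccs3)cc(-c3cccc(O)c3)n2)cc1`: 1890 nM

Compound 1 reached only a limit, > 50000 nM. That leaves two true numbers, and the higher belongs to compound 2, at 9300 nM, which makes it the weaker inhibitor of that pair.

Compound 4 `Oc1cccc(-c2cc(-c3ccoc3)cc(-c3ccccc3O)n2)c1`, not yet measured, keeps both hydroxyphenyl groups of compound 2 and changes one ring: furan-3-yl in place of thiophen-2-yl on an aromatic carbon. This puts furan-3-yl in place of thiophen-2-yl on an aromatic carbon, opposite the ring nitrogen.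

Two measured steps exist, an at least 5.3-fold lower number from compound 1 to compound 2 (0.73 log units; beyond the scatter) and a 4.9-fold lower number from compound 2 to compound 3 (0.69 log units; beyond the scatter). Both lie beyond the scatter, but both change a hydroxyphenyl group, and neither touches the thiophen-2-yl group. They show that these compounds can differ in this assay, yet they give no direction for this swap. No step beyond the scatter is therefore expected, though with wide uncertainty. The estimated change is a 1.0-fold lower number from compound 2 to compound 4 (0.01 log units; within the scatter). For compound 4 the expected value is 9000 nM, with an estimated range of 3000 nM to 27000 nM.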

Compound 4, half-maximal inhibitory concentration: 2790 nM
For compound 4 the middle estimate is 3.2-fold (0.51 log units) above the measured one; measured number below the stated range.
By their numbers in this assay, from the lowest: compounds 3 and 4 (each within the scatter of the next); then compound 2. At a limit, above all of these: compound 1.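

Until this result, every measured step had changed a hydroxyphenyl group, so the position opposite the ring nitrogen had shown nothing. The change to furan-3-yl gives a 3.3-fold lower number from compound 2 to compound 4 (0.52 log units; beyond the scatter) in this assay and shows that the ring held at this position matters, even though thiophen-2-yl and furan-3-yl are both five-membered aromatic rings with 1 hetero atom and the same count of heavy atoms. Nothing measured here bears on why this swap lowers the number.

Going by these compounds, whether the same swap would also lower the number on the hydroxyphenyl patterns of compound 1 or compound 3 remains open. Also open, on these data alone, is how an amine, a carboxylic acid or a longer chain would behave at this position opposite the ring nitrogen.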